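The source may hold more compounds than are shown below. What is called first, only, known or untested is meant among the compounds shown, and "the series" means these compounds.

The measured compounds in an assay on HEK293 cells for antagonist activity at Toll-like receptor 9 (Homo sapiens), read by spectrophotometry; a higher number here means a weaker inhibitor, a lower number a stronger inhibitor:
compound 1, `Nc1nc(N2CCN(C3CCCC3)CC2)c2ncn(CCCN3CCCC3)c2n1`, 120 nM;
compound 2, `CCN1CCN(CCCn2cnc3c(N4CCN(CC)CC4)ncnc32)CC1`, 1190 nM;
compound 3, `CCN1CCN(CCCn2cnc3c(N4CCN(C(=O)C5CCCC5)CC4)nc(NCc4ccc(OC)cc4)nc32)CC1`, recorded as a limit only.

Compound 2 has the higher of the two numbers, and its gap to compound 1 is beyond the usual scatter of repeated measurements. For compound 3 the result is > 30000 nM, which is a limit of the measurement rather than a number. Compound 3 thus sits at the limit of > 30000 nM in this assay, at which 1 of the 3 values shown sits. Both compound 1 and compound 3 differ from compound 2 in more than one place, so no single change can be read off from them.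

Compound 4, `CCN1CCN(CCCn2cnc3c(N4CCN(CC)CC4)nc(NCc4ccc(F)cc4)nc32)CC1`, has not yet been measured. It differs from compound 2 in one place: (4-fluorobenzyl)amino in place of hydrogen on an aromatic carbon

Among the compounds with values here, no measured pair shows this change on its own, so the expected step in this assay from compound 2 to compound 4 is a modest one, with no clear direction, and its expected size is a 1.3-fold higher number from compound 2 to compound 4 (0.10 log units; within the scatter). Compound 4 is therefore expected to give about 1500 nM in this assay, within a range from 300 nM to 10000 nM.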

Compound 4, half-maximal inhibitory concentration: 470 nM
Compound 4: middle estimate off by 3.2-fold (0.50 log units), on the high side; the range from low to high includes it.
By their numbers in this assay, from the lowest: compound 1; then compound 4; then compound 2. At a limit, above all of these: compound 3.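

Putting (4-fluorobenzyl)amino in place of hydrogen on this aromatic carbon, between two ring nitrogen atoms, gives a 2.5-fold lower number from compound 2 to compound 4 (0.40 log units; beyond the scatter) in this assay. Within the data shown here, this is the first single change that can be read in this set, and it shows that a substituent carrying a six-membered aromatic ring can sit at this position without the number rising. Nothing measured here accounts for the step, so it stands as an observation only.

From the compounds shown here alone, it remains open whether the fluorine takes part in this step: a plain benzylamino group, with hydrogen in its place, would separate the effect of the fluorine from that of the rest of the group. Going by these compounds, it is also open how a longer chain at this position, such as 2-phenylethylamino, would behave.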